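A Ring Enters the Amide Side Chain of Compound 3

The source may report more compounds than this note shows. Statements on the series, on what has been measured and on what is new or still open speak of the compounds shown alone.

In a functional assay on PANC-1 cells (Homo sapiens) for antiproliferative activity, read by MTT assay, with a stated time of 48 h (on this read-out higher numbers stand for weaker inhibition and lower numbers for stronger inhibition), compound 1 (`Cc1c(C(=O)NCCCN(C)C)oc2ccc(N(Cc3ccc(Br)cc3)S(=O)(=O)c3ccc(Br)cc3)cc12`) gives 2300 nM. Compound 2 (`Cc1c(C(=O)NCCS(C)(=O)=O)oc2ccc(N(Cc3ccc(Br)cc3)S(=O)(=O)c3ccc(Br)cc3)cc12`) gives > 40000 nM, which is a limit of the assay and not a number. Compound 3 (`CN(C)CCNC(=O)c1nc2cc(N(Cc3ccc(Br)cc3)S(=O)(=O)c3ccc(Br)cc3)ccc2o1`) has a different core and carries 2-(dimethylamino)ethyl on an amide-type nitrogen, and compound 3 gives 13600 nM. That is the higher of the two true numbers, with compound 1 holding the lower one.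

Compound 4 (`CN1CCC(NC(=O)c2nc3cc(N(Cc4ccc(Br)cc4)S(=O)(=O)c4ccc(Br)cc4)ccc3o2)CC1`) has 1-methylpiperidin-4-yl in place of 2-(dimethylamino)ethyl on an amide-type nitrogen. Going by the values given here, only one measured step bears on this change, and only indirectly. The large step of an at least 17-fold higher number from compound 1 to compound 2 (1.24 log units; beyond the scatter) came with methylsulfonyl in place of (dimethylamino)methyl, so the nitrogen of the chain was lost. Compound 4 keeps a nitrogen in its new group, so no loss of that size is expected. Among the compounds with values here, no measured step turns an open chain into a ring, so a shift in either direction remains possible. The expected change is a 1.2-fold lower number from compound 3 to compound 4 (0.09 log units; within the scatter), which would be no step beyond the scatter in this assay. The estimate for compound 4 is 11000 nM, with an expected range from 3500 nM to 32000 nM.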

Compound 4, half-maximal inhibitory concentration: 5910 nM
Estimate against measurement, compound 4: 1.9-fold (0.27 log units) above; the measured number falls inside the stated range.
By their numbers in this assay, from the lowest: compound 1; then compound 4; then compound 3. At a limit, above all of these: compound 2.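

In this assay, putting 1-methylpiperidin-4-yl in place of 2-(dimethylamino)ethyl on an amide-type nitrogen gives a 2.3-fold lower number from compound 3 to compound 4 (0.36 log units; beyond the scatter), a modest step but one that clears the usual scatter. Going by these compounds alone, the only earlier step in the side chain, an at least 17-fold higher number from compound 1 to compound 2 (1.24 log units; beyond the scatter), removed the chain nitrogen, whereas here a nitrogen stays in the entering group, the heavy-atom count rises from 5 to 7, and a six-membered non-aromatic ring appears, so this side chain can take a larger, ring-bearing group with no loss of inhibition on the core of compound 3. Nothing measured here explains why the ring version gives the lower number.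

The compounds shown cannot separate the ring itself from the added carbon atoms or from the methyl on the ring nitrogen, and a plain piperidin-4-yl group or a morpholine ring, in which an oxygen atom joins the nitrogen, would begin to pull these apart. It also stays open whether 1-methylpiperidin-4-yl would bring a similar step on the core of compound 1, since no pair shown tests the same change on both cores.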